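This account rests on a few compounds, and the source may have more. Where it says the series, first, only, none or still open, it means among the compounds named here.

In a functional assay on HeLa cells (Homo sapiens) for cytotoxicity, read by MTT assay, with a stated time of 24 h (on this read-out higher numbers stand for weaker inhibition and lower numbers for stronger inhibition), three compounds have been tested so far. Among the measured compounds shown here, compound 1, `O=c1nc2ccccn2cc1Cc1ccc(F)cc1C(F)(F)F`, gives 88000 nM, the only actual number among them. Compound 2, `CC1(C)OC2O[C@@H](Cc3cn4ccccc4nc3=O)C(OCc3ccccc3)C2O1`, reads > 1000000 nM, which is a limit of the assay and not a number. Compound 3, `O=c1nc2ccc(Br)cn2cc1Cc1ccc(Cl)cc1`, which carries no trifluoromethyl, reads > 1000000 nM, also a limit. For the measured compounds named here, compound 1 is therefore the one compound that stands clear of the limit of > 1000000 nM in this assay, at which 2 of the 3 values shown sit.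

Compound 4, `O=c1nc2ccccn2cc1Cc1ccc(F)cc1`, has not yet been measured. It differs from compound 1 by a single change, hydrogen in place of trifluoromethyl on an aromatic carbon. Going by the values given here, no step between measured compounds gives the size of such a change, so the expectation rests only on the few readings in this assay. Given the limit reached by compound 3 at > 1000000 nM, a move towards weaker inhibition, beyond the usual scatter, is expected rather than no change. The expected step is a 3.4-fold higher number from compound 1 to compound 4 (0.53 log units; beyond the scatter). Compound 4 is estimated at 300000 nM, within an expected range of 90000 nM to 1000000 nM.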

Compound 4, half-maximal inhibitory concentration: 139000 nM
Beside the measured number, compound 4's estimate is 2.2-fold (0.33 log units) above it; the range from low to high includes it.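

Hydrogen in place of trifluoromethyl on this aromatic carbon gives, in this assay, a 1.6-fold higher number from compound 1 to compound 4 (0.20 log units; within the scatter). At this position, then, losing the trifluoromethyl and its 4 heavy atoms produces no change that can be told apart from the scatter of repeated measurements. Compound 4, like compound 1, gives an actual number and not a limit, so the trifluoromethyl is not required for a reading clear of it: the limit of > 1000000 nM in this assay, at which 2 of the 4 values shown sit.

As far as these compounds go, what an amine, a carboxylic acid or a methoxy group on this carbon would do to the number remains open. Also open, from the compounds shown here alone, is whether the same replacement would read alike if the fluoro group were absent from the ring.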